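The compounds below may be only part of what the source reports. "The series", "measured", "known", "first", "only" and "open" are said of these compounds alone.

Measured so far in an assay on isolated protein for inhibition of histone deacetylase 4 (Homo sapiens), read by fluorescence; on this read-out lower numbers stand for stronger inhibition and higher numbers for weaker inhibition:
compound 1 `CCCN(CCC)C[C@@H](C)NC(=O)c1ccc(-c2noc(C(F)F)n2)cc1` — 890 nM
compound 2 `C[C@H](CN1CCC(F)(F)CC1)NC(=O)c1ccc(-c2noc(C(F)(F)F)n2)cc1` — 130 nM
compound 3 `O=C(NC1(CN2CCCC2)CC1)c1ccc(-c2noc(C(F)(F)F)n2)cc1` — 40 nM

Compound 1 gives the highest number of the three. Compound 2 lies well below it and compound 3 lower still; both gaps from compound 1 are beyond the scatter, so compound 1 is the weakest inhibitor of the set in this assay. Neither compound 2 nor compound 3 differs from compound 1 in a single place, so no gap here can be tied to one change; it is only noted that the two compounds with lower numbers carry a trifluoromethyl on the five-membered ring, together with other differences.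

Compound 4 `CCCN(CCC)C[C@@H](C)NC(=O)c1ccc(-c2noc(C)n2)cc1` differs from compound 1 in one place: methyl in place of difluoromethyl on an aromatic carbon. Among the measured compounds shown here, with no single-change step available, the expectation rests on the direction of the three numbers alone. Compound 4 is expected to be a weaker inhibitor than compound 1 in this assay, with a step of a 5.6-fold higher number from compound 1 to compound 4 (0.75 log units; beyond the scatter), beyond the scatter. Compound 4 is estimated at 5000 nM, within 1500 nM to 20000 nM.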

Compound 4, half-maximal inhibitory concentration: > 50000 nM
Compound 4: only a limit was reported (the forecaster's own chance of this, stated with the estimate: 25%); middle value at least 10-fold (1.00 log units) from the limit.
By their numbers in this assay, from the lowest: compound 3; then compound 2; then compound 1. At a limit, above all of these: compound 4.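

In this assay, among the compounds shown here, the single change from 5-(difluoromethyl)-1,2,4-oxadiazol-3-yl to 5-methyl-1,2,4-oxadiazol-3-yl gives an at least 56-fold higher number from compound 1 to compound 4 (1.74 log units; beyond the scatter), the only step that can be tied to one place. Inhibition in this assay therefore depends strongly on the group at this aromatic carbon, and with the rest of compound 1 held constant, methyl does not retain the inhibition seen with difluoromethyl. For compound 4 the reported value is a limit of the assay, not a number: the limit of > 50000 nM in this assay, at which 1 of the 4 values shown sits.

Still open, from the compounds shown here alone, is how trifluoromethyl at this carbon would read with the rest of compound 1 held constant, as compound 2 and compound 3 carry it only together with other differences. Also open, going by these compounds, are the true size of the step and what monofluoromethyl or ethyl would give at this position.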